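The source may hold more compounds than are shown below. What is called first, only, known or untested is meant among the compounds shown, and "the series" means these compounds.

Measured compounds:
compound 2 `COc1ccc(C2=NOC(c3ccc(C)cc3)C2S(=O)(=O)CC2=NCCO2)cc1`, 66.6% in a functional assay, tested at 75 ug/mL; a lower number here means a weaker effect, a higher number a stronger effect of the compound at the concentration tested;
compound 3 `COc1ccc(C2=NOC(c3ccc(C)cc3)C2S(=O)(=O)CC2=NCCS2)cc1`, 49.7% in this assay;
compound 1 `O=S(=O)(CC1=NCCS1)C1C(c2ccccc2)=NN(c2ccccc2)C1c1ccccc1`, "not active" (no number reported) in this assay, with no number.

Compound 2 and compound 3 share one core and differ only in a group of 5 heavy atoms (3 carbon, 1 nitrogen, 1 oxygen; one five-membered non-aromatic ring with 2 hetero atoms) in place of a group of 5 heavy atoms (3 carbon, 1 nitrogen, 1 sulfur; one five-membered non-aromatic ring with 2 hetero atoms), on a saturated chain carbon bound to a sulfonyl sulfur. That change made a step of a number 16.9 percentage points higher from compound 3 to compound 2 (beyond the scatter). Compound 4 `O=S(=O)(CC1=NCCO1)C1C(c2ccccc2)=NN(c2ccccc2)C1c1ccccc1` is not yet measured; it differs from compound 1 in a group of 5 heavy atoms (3 carbon, 1 nitrogen, 1 oxygen; one five-membered non-aromatic ring with 2 hetero atoms) in place of a group of 5 heavy atoms (3 carbon, 1 nitrogen, 1 sulfur; one five-membered non-aromatic ring with 2 hetero atoms), on a saturated chain carbon bound to a sulfonyl sulfur, which is the same change made on the core of compound 1. The difference between the two cores is not broken down here. Among the measured compounds shown here, compound 1 gave no number in this assay, so no step can be computed for compound 4 and the estimate rests on the earlier step alone, carried onto a core that showed no activity. Compound 4 is therefore expected to stay weak, around 15%, within 0% to 40%.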

Compound 4, a percentage reported as activity, at one concentration (the size of the read-out at that concentration, not a potency): 45.5%
Beside the measured number, compound 4's estimate is 30.5 percentage points below it; measured number outside the range, above it.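

In this assay, among the compounds shown here, compound 1 gives "not active" (no number reported), and no step from it to compound 4 can be read. The compounds shown leave open how large the ring change is on this core, and no evidence bears on the result.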